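Methoxy for Chloro with Solubility at the Ceiling

The source may hold more compounds than are shown below. What is called first, only, known or untested is meant among the compounds shown, and "the series" means these compounds.

Of the compounds shown here, three sharing one core have been tested in a physicochemical assay for solubility, at pH 2; on this read-out higher numbers stand for higher solubility and lower numbers for lower solubility. Compound 1, `CSCCNc1nc(NC(C)C)nc2ccccc12`, gives >= 30000 nM in this assay, a value that is a limit of the measurement rather than a number. Compound 3, `Cc1ccc2nc(NC(C)C)nc(NCc3ccco3)c2c1`, likewise gives >= 30000 nM in this assay, again a limit. Compound 2, `CC(C)Nc1nc(NCc2ccco2)c2cccc(Cl)c2n1`, stands at >= 30000 nM in this assay, which is also a limit. All three values sit at the same ceiling, (the limit of >= 30000 nM in this assay, at which 3 of the 3 values shown sit), so no difference among them can be read, and compound 2 cannot be placed above or below the other two.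

The next compound, compound 4, `COc1cccc2c(NCc3ccco3)nc(NC(C)C)nc12`, differs from compound 2 in a single place: methoxy in place of chloro on an aromatic carbon. Going by the values given here, no step between measured compounds is known that would show what such a change does to solubility, so the expectation rests only on where the measured values stand. The step from compound 2 to compound 4 is expected to be none beyond the scatter, a number no higher from compound 2 to compound 4 (the limit leaves the size open), with the result most likely reported once more as a limit. Compound 4 is therefore estimated at 30000 nM in this assay, with a range from 15000 nM to 60000 nM.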

Compound 4, solubility: >= 30000 nM
Compound 4: only a limit was reported; the forecaster's own chance of this, stated with the estimate: 85%; the middle value lies on the limit itself.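

No step can be read from compound 2 to compound 4 in this assay, because both results are limits rather than numbers: the limit of >= 30000 nM in this assay, at which 4 of the 4 values shown sit.

The compounds shown leave open whether methoxy in place of chloro on an aromatic carbon changes solubility at all, and how the true solubilities of these compounds compare.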